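The source may report more compounds than this note shows. Statements on the series, on what has been measured and on what is new or still open speak of the compounds shown alone.

Measured in a functional assay on HT-29 cells (Homo sapiens) for antiproliferative activity, read by MTT assay, with a stated time of 72 h; on this read-out lower numbers stand for stronger inhibition and higher numbers for weaker inhibition:
- compound 1, `O=C(Nc1ccc(Oc2ccnc3[nH]ccc23)cc1)c1cc2cccnc2n(-c2ccccc2)c1=O`, gives 290 nM
- compound 2, `O=C(Nc1ccc(Oc2ccnc3[nH]ccc23)cc1)c1cc2cccnc2n(-c2ccc(F)cc2)c1=O`, gives 160 nM
- compound 3, `Cn1ccc2c(Oc3ccc(NC(=O)c4cc5cccnc5n(-c5ccccc5)c4=O)cc3F)ccnc21`, gives 510 nM

Compound 1 and compound 2 share the same core; compound 2 differs from compound 1 only by fluoro in place of hydrogen on an aromatic carbon. The matched step is a 1.8-fold lower number from compound 1 to compound 2 (0.26 log units; within the scatter), so the pair does not separate on this read-out.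

Compound 3 carries a different core. The difference between the two cores is not broken down here. Compound 3 returns the highest of the three numbers; its gap to compound 1 is within the scatter, while its gap to compound 2 is beyond the scatter.

Compound 4, `Cn1ccc2c(Oc3ccc(NC(=O)c4cc5cccnc5n(-c5ccc(F)cc5)c4=O)cc3F)ccnc21`, has not yet been measured in this assay. It is built from compound 3 by fluoro in place of hydrogen on an aromatic carbon. The descriptions of the place are identical word for word for both pairs, so this is the same change as from compound 1 to compound 2, and it appears twice among the four compounds.

Within the data shown here, only one measured instance of the change exists. Because the earlier step reads a 1.8-fold lower number from compound 1 to compound 2 (0.26 log units; within the scatter), a step of comparable, modest size is expected from compound 3 to compound 4, namely a 1.7-fold lower number from compound 3 to compound 4 (0.23 log units; within the scatter). The estimate for compound 4 in this assay is 300 nM. Given that it rests on a single pair and a core that is not otherwise characterised, compound 4 is expected to lie between 140 nM and 700 nM.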

Compound 4, half-maximal inhibitory concentration: 160 nM
For compound 4 the middle estimate is 1.9-fold (0.27 log units) above the measured one; the range from low to high includes it.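

On the core of compound 3, phenyl to 4-fluorophenyl gives in this assay a 3.2-fold lower number from compound 3 to compound 4 (0.50 log units; beyond the scatter). Set beside the earlier instance of the change, this step shows no difference in size that the data can separate, so on these two cores the change carries over as far as this read-out can tell: the same change on two cores in this assay, a 1.8-fold lower number (0.26 log units; within the scatter) from compound 1 to compound 2 and a 3.2-fold lower number (0.50 log units; beyond the scatter) from compound 3 to compound 4, 1.8-fold (0.25 log units) apart, within the scatter of two such steps This does not establish a general rule for the series: the comparison rests on a single pair per core, only the step on the core of compound 3 lies beyond the scatter, and two cores say nothing about how the change would read on a third, nor do the numbers give any reason for the step.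

The compounds shown leave open how another group at the same place on the six-membered aromatic ring, such as chloro, methoxy, an amine or a carboxylic acid, would read against hydrogen and fluoro on either core. Among these compounds, they also leave open which of the differences between the two cores matters on this read-out, as no pair separates those differences one at a time.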